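Swapping Fluoro for Nitro on the Benzyl Arm

The source may hold more compounds than are shown below. What is called first, only, known or untested is meant among the compounds shown, and "the series" means these compounds.

All numbers here come from a toxicity assay on GES1 cells (Homo sapiens) for inhibition, read by MTT assay, with a stated time of 72 h; on this read-out lower numbers stand for stronger inhibition and higher numbers for weaker inhibition.
compound 1 `Cc1cc(N2CC[C@@H](C)[C@@H](N(C)c3ncnc4[nH]ccc34)C2)n2ncnc2n1`: 57900 nM
compound 2 `Cc1cc(N2CC[C@@H](C)[C@@H](N(C)c3ncnc4[nH]ccc34)C2)n2nc(SCc3ccc(F)cc3)nc2n1`: 12300 nM
compound 3 `Cc1cc(N2CC[C@@H](C)[C@@H](N(C)c3ncnc4[nH]ccc34)C2)n2nc(SCc3ccc(F)c(Cl)c3)nc2n1`: > 100000 nM, which is a limit of the assay and not a number.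

Compound 2 gives the lowest of the two numbers; its nearest neighbour is compound 1, and the step of a 4.7-fold lower number from compound 1 to compound 2 (0.67 log units; beyond the scatter) lies beyond the scatter. Compound 4 `Cc1cc(N2CC[C@@H](C)[C@@H](N(C)c3ncnc4[nH]ccc34)C2)n2nc(SCc3ccc([N+](=O)[O-])cc3)nc2n1` has not been measured. It differs from compound 2 in one place: nitro in place of fluoro on an aromatic carbon.

Among the compounds with values here, two measured steps bear on this. The step of a 4.7-fold lower number from compound 1 to compound 2 (0.67 log units; beyond the scatter) shows that attaching the (4-fluorobenzyl)sulfanyl group lowered the number. The step of an at least 8.1-fold higher number from compound 2 to compound 3 (0.91 log units; beyond the scatter) shows that a further change on that same benzyl ring pushed the value up to the limit (the limit of > 100000 nM in this assay, at which 1 of the 3 values shown sits). A nitro in place of fluoro on that ring is therefore expected to raise the number in this assay, though by an uncertain amount: the estimated step is a 2.8-fold higher number from compound 2 to compound 4 (0.45 log units; beyond the scatter). Compound 4 is expected to give about 35000 nM, within a range from 10000 nM to 120000 nM.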

Compound 4, half-maximal inhibitory concentration: 36600 nM
Compound 4: the middle estimate sits 1.0-fold (0.02 log units) below what was measured; the measured number falls inside the stated range.
By their numbers in this assay, from the lowest: compound 2; then compounds 4 and 1 (each within the scatter of the next). At a limit, above all of these: compound 3.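

Changing only the group at this one ring position, with no second group added, is enough to move the reading: nitro in place of fluoro gives a 3.0-fold higher number from compound 2 to compound 4 (0.47 log units; beyond the scatter). The lowering that came with the (4-fluorobenzyl)sulfanyl arm therefore does not carry over to every arm of this kind, since the (4-nitrobenzyl)sulfanyl arm gives a 1.6-fold lower number from compound 1 to compound 4 (0.20 log units; within the scatter), and compound 4 cannot be told apart from compound 1, which lacks the arm. The step of an at least 2.7-fold lower number from compound 3 to compound 4 (0.43 log units; beyond the scatter) shows that not every change on this ring reaches the value of compound 3, which is a limit and not a number: the limit of > 100000 nM in this assay, at which 1 of the 4 values shown sits.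

Fluoro and nitro alone are too few to set a trend at this position. From the compounds shown here alone, whether an amine, a methyl or a carboxylic acid there would read closer to compound 2 or to compound 1 remains open.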